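Ether aryl swap in the melanin-concentrating hormone receptor series

This account rests on a few compounds, and the source may have more. Where it says the series, first, only, none or still open, it means among the compounds named here.

Compound 1 `Cn1c(C2CC2)nc2ccc(-n3ccc(OCc4ccc(F)cc4)cc3=O)cc21` gives 40 nM in an assay on CHO cells for displacement of a labelled ligand from melanin-concentrating hormone receptor 1 (Homo sapiens), read by scintillation counting, with a stated time of 1 h (a higher number here means a weaker inhibitor, a lower number a stronger inhibitor), and stands lowest of the two numbers measured. Compound 2 `Cn1c(C2CCC2)nc2ccc(-n3ccc(OCc4ccc(F)cc4)cc3=O)cc21` gives 240 nM in this assay. Within the data shown here, the only measured step, a 6.0-fold higher number from compound 1 to compound 2 (0.78 log units; beyond the scatter), concerns the small ring on the aromatic carbon of the shared core, not the ether end. Compound 3 `Cn1c(C2CC2)nc2ccc(-n3ccc(OCc4cc(C(F)(F)F)cs4)cc3=O)cc21` carries 4-(trifluoromethyl)thiophen-2-yl in place of 4-fluorophenyl on a saturated chain carbon bound to an oxygen on an aromatic ring, with the cyclopropyl of compound 1 kept. Among the measured compounds shown here, no measured step bears on this change, so the step of a 1.3-fold higher number from compound 1 to compound 3 (0.10 log units; within the scatter) is expected to be small, in either direction, with wide uncertainty. Compound 3 is estimated at 50 nM, within 12 nM to 200 nM.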

Compound 3, half-maximal inhibitory concentration: 34 nM
Estimate against measurement, compound 3: 1.5-fold (0.17 log units) above, and the stated range covers the measured number.
By their numbers in this assay, from the lowest: compounds 3 and 1 (each within the scatter of the next); then compound 2.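

The ether end now has a measured step: 4-(trifluoromethyl)thiophen-2-yl in place of 4-fluorophenyl gives a 1.2-fold lower number from compound 1 to compound 3 (0.07 log units; within the scatter) in this assay. On a saturated chain carbon bound to an oxygen on an aromatic ring, a five-membered aromatic ring with 1 hetero atom thus stands in for the six-membered ring of carbon only, without a step beyond the scatter. No measurement at hand accounts for this match.

From the compounds shown here alone, whether this place also accepts a group without an aromatic ring, such as an amine or a carboxylic acid, stays open. So does whether cyclobutyl in place of cyclopropyl behaves alike with 4-(trifluoromethyl)thiophen-2-yl at the ether end.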